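Propyl in place of isopropyl, tried on a second core

The source may hold more compounds than are shown below. What is called first, only, known or untested is meant among the compounds shown, and "the series" means these compounds.

Compound 1 `COc1cc2ncnc(N3CCc4ccccc43)c2cc1NC(=O)/C=C/C(C)C` carries isopropyl on a double-bonded chain carbon bound to a double-bonded chain carbon; in a functional assay on PC-3 cells (Homo sapiens) for antiproliferative activity, read by MTT assay, with a stated time of 72 h (a higher number here means a weaker inhibitor, a lower number a stronger inhibitor), compound 1 gives 6530 nM. Compound 2 `CCC/C=C/C(=O)Nc1cc2c(N3CCc4ccccc43)ncnc2cc1OC` differs from it by propyl in place of isopropyl on a double-bonded chain carbon bound to a double-bonded chain carbon and in this assay compound 2 gives 4240 nM; the step is a 1.5-fold lower number from compound 1 to compound 2 (0.19 log units; within the scatter). Compound 3 `COc1cc2ncnc(N3CCCc4ccccc43)c2cc1NC(=O)/C=C/C(C)C` keeps the isopropyl but its core differs from the core of compound 1 by 1,2,3,4-tetrahydroquinolin-1-yl in place of 2,3-dihydro-1H-indol-1-yl on an aromatic carbon; in this assay compound 3 gives 8430 nM, and the step is a 1.3-fold higher number from compound 1 to compound 3 (0.11 log units; within the scatter). All three values lie within the scatter of one another, so no order among them is claimed.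

Compound 4 `CCC/C=C/C(=O)Nc1cc2c(N3CCCc4ccccc43)ncnc2cc1OC` has not yet been measured. It differs from compound 3 by propyl in place of isopropyl on a double-bonded chain carbon bound to a double-bonded chain carbon. This is the same change as that from compound 1 to compound 2, made at the same place, on a double-bonded chain carbon bound to a double-bonded chain carbon, and it appears in two pairs among these compounds. Within the data shown here, the one measured instance is a 1.5-fold lower number from compound 1 to compound 2 (0.19 log units; within the scatter), a step within the scatter, and it is the single precedent relied on here. The step from compound 3 to compound 4 in this assay is therefore expected to be a 1.5-fold lower number from compound 3 to compound 4 (0.19 log units; within the scatter), in the same direction and of about the same small size. Compound 4 is therefore estimated at 5500 nM in this assay, with a range from 2700 nM to 11000 nM.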

Compound 4, half-maximal inhibitory concentration: 2240 nM
For compound 4 the middle estimate is 2.5-fold (0.39 log units) above the measured one; the measured number lies below the stated range.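

In this assay, propyl in place of isopropyl gives a 3.8-fold lower number from compound 3 to compound 4 (0.58 log units; beyond the scatter), a step beyond the scatter, whereas the earlier step on the core of compound 1 stays within it, yet the gap between the two steps is itself within the scatter: the same change on two cores in this assay, a 1.5-fold lower number (0.19 log units; within the scatter) from compound 1 to compound 2 and a 3.8-fold lower number (0.58 log units; beyond the scatter) from compound 3 to compound 4, 2.4-fold (0.39 log units) apart, within the scatter of two such steps. The core change read with propyl in place gives a 1.9-fold lower number from compound 2 to compound 4 (0.28 log units; within the scatter), also within the scatter, and it cannot be told apart from the same core change read with isopropyl in place: the same change on two cores in this assay, a 1.3-fold higher number (0.11 log units; within the scatter) from compound 1 to compound 3 and a 1.9-fold lower number (0.28 log units; within the scatter) from compound 2 to compound 4, 2.4-fold (0.39 log units) apart, within the scatter of two such steps. Among these compounds, the two pairs are thus compatible with the change carrying over from one core to the other with a single effect, but they do not show that its size depends on the core, nor, with only two pairs and one of them within the scatter, that it would lower the number on every core.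

The compounds shown leave open how a longer chain, such as butyl, or a dimethylamino group would compare with propyl and isopropyl on a double-bonded chain carbon bound to a double-bonded chain carbon. They also leave open whether the step seen on the core of compound 3 would recur on a third core.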